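The compounds below may be only part of what the source reports. "The series", "measured", "known", "first", "only" and "open" are said of these compounds alone.

Compound 1, with the structure `CCOc1ccc(NC(=O)c2cccc(/C=C3\CC(=O)N(c4ccccc4)C3=O)c2)cc1`, is one of three compounds for which a result is known in an ADME assay on SW480 cells (Homo sapiens) for cytotoxicity, read by MTT assay, with a stated time of 72 h (a lower number here means a stronger inhibitor, a higher number a weaker inhibitor), and compound 1 itself gives 91500 nM. Compound 2, whose structure is `CCCCCN1C(=O)C/C(=C\c2cccc(C(=O)Nc3cccc(CC)c3)c2)C1=O`, gives 83300 nM in this assay, and the two numbers for compound 1 and compound 2 lie within the usual scatter of each other, so neither can be placed ahead of the other. The third compound, compound 3 with the structure `O=C(Nc1ccc(Cl)cc1)c1cccc(/C=C2\CC(=O)N(Cc3ccccc3)C2=O)c1`, reaches only the limit of this assay, reported as > 100000 nM. That limit is the limit of > 100000 nM in this assay, at which 1 of the 3 values shown sits. No two of these three compounds differ in a single place, so no measured step can be read from them.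

Compound 4, with the structure `O=C(NCc1ccccc1)c1cccc(/C=C2\CC(=O)N(c3ccccc3)C2=O)c1`, has not been measured in this assay. It differs from compound 1 in one place: benzyl in place of 4-ethoxyphenyl on an amide-type nitrogen. Among the compounds with values here, with no measured step of this kind among the three compounds, the account can only lean on how close together all three sit. The expected step from compound 1 to compound 4 in this assay is a 1.1-fold higher number from compound 1 to compound 4 (0.04 log units; within the scatter), a change not expected to exceed the scatter. Compound 4 is therefore estimated at 100000 nM, within a range from 50000 nM to 200000 nM.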

Compound 4, half-maximal inhibitory concentration: > 100000 nM
Compound 4 was reported as a limit; the forecaster's own chance of this, stated with the estimate: 40%; the middle value sits exactly at the limit.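

In this assay compound 4 gives a limit and not a number: > 100000 nM. This is the only single-place step among the compounds shown, and it is a floor rather than a size: an at least 1.0-fold higher number from compound 1 to compound 4 (0.03 log units; that floor lies within the scatter). It shows that, on this amide-type nitrogen, neither benzyl nor 4-ethoxyphenyl gives a result that stands clearly apart from the other, and that the loss of the ethoxy oxygen brings no sign of a stronger inhibitor, while the limit now holds more of the compounds shown: the limit of > 100000 nM in this assay, at which 2 of the 4 values shown sit.

As far as these compounds go, how far compound 4 lies past its limit cannot be read, so the true size of this step stays unknown. From the compounds shown here alone, it also stays open whether any other group on this nitrogen, such as a carboxylic acid, an amine or a longer alkyl chain, would give a number that moves beyond the scatter, since the two groups compared here both carry a six-membered aromatic ring of carbon only.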